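The source may hold more compounds than are shown below. What is called first, only, known or untested is meant among the compounds shown, and "the series" means these compounds.

Compound 1 `COc1ccc(-c2nc3ccccn3c2Sc2ccccc2)cc1`: > 100000 nM (a limit of the assay, not a number)
Compound 2 `CSc1ccc(-c2nc3ccccn3c2Sc2ccccc2)cc1`: 30000 nM
Compound 3 `Clc1ccc(Sc2c(-c3cccs3)nc3ccccn23)cc1`: 74100 nM

These results come from a functional assay on HeLa cells (Homo sapiens) for inhibition, read by MTT assay, with a stated time of 48 h; on this read-out lower numbers stand for stronger inhibition and higher numbers for weaker inhibition. Compound 2 has the lower of the two true numbers. The nearest number belongs to compound 3, at 74100 nM. The entry for compound 1 is a limit, as the limit of > 100000 nM in this assay, at which 1 of the 3 values shown sits, records.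

Compound 4 `Clc1ccc(-c2nc3ccccn3c2Sc2ccccc2)cc1` has chloro in place of methylsulfanyl on an aromatic carbon, para to a large group, compared with compound 2: chloro in place of methylsulfanyl on an aromatic carbon. Within the data shown here, only one measured step involves the group that leaves: an at least 3.3-fold lower number from compound 1 to compound 2 (0.52 log units; beyond the scatter), which put methylsulfanyl in place of methoxy. It does not test chloro, so it offers only a rough guide. Compound 3 also carries chloro but differs elsewhere as well. Removing methylsulfanyl may give back part of the gain seen in that step, so a small rise in the number is expected in this assay. The expected step is a 1.7-fold higher number from compound 2 to compound 4 (0.22 log units; within the scatter). For compound 4 the estimate is 50000 nM, with an expected range from 20000 nM to 100000 nM.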

Compound 4, half-maximal inhibitory concentration: 62000 nM
Compound 4: the middle estimate sits 1.2-fold (0.09 log units) below what was measured; low and high end bracket the measured number.
By their numbers in this assay, from the lowest: compound 2; then compounds 4 and 3 (each within the scatter of the next). At a limit, above all of these: compound 1.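

In this assay, the lower number of compound 2 is now tested against a second replacement at this position, and the change is modest but clear: a 2.1-fold higher number from compound 2 to compound 4 (0.32 log units; beyond the scatter). So, among the groups compared here, methylsulfanyl gives the lowest number, and that edge holds against chloro as well as methoxy, though all these numbers remain high. Chloro cannot be separated from methoxy with any confidence, as the comparison gives only a floor within the usual scatter, an at least 1.6-fold lower number from compound 1 to compound 4 (0.20 log units; that floor lies within the scatter), and compound 1 stands at a limit, not a number: the limit of > 100000 nM in this assay, at which 1 of the 4 values shown sits.

Going by these compounds, it remains open whether a longer chain such as ethylsulfanyl, an amine or a carboxylic acid at this position would lower the number further. On these data alone, it is equally open whether methylsulfanyl would keep its edge on the core of compound 3.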